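The source may report more compounds than this note shows. Statements on the series, on what has been measured and on what is new or still open speak of the compounds shown alone.

Measured compounds:
- compound 1 `Nc1ncnc2c1ncn2C[C@@H]1C[C@H](O)c2ccccc21`: > 200000 nM
- compound 2 `CO[C@@H]1OC(n2cc(F)c(=O)[nH]c2=O)[C@H](OC(C)=O)[C@@H](OC(C)=O)[C@H]1F`: 34000 nM
- compound 3 `O=c1[nH]c(=O)n([C@H]2C[C@H](O)[C@@H](CO)O2)cc1/C=C/I`: 63900 nM

All three were read in an ADME assay on L1210/0 cells (Mus musculus) for cytotoxicity, with a stated time of 48 h; on this read-out lower numbers stand for stronger inhibition and higher numbers for weaker inhibition. The entry for compound 1 is a limit of the assay, not a number: > 200000 nM. The two true numbers, compound 3 at 63900 nM and compound 2 at 34000 nM, lie within the scatter of each other.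

Compound 4 `C=Cc1cn([C@H]2C[C@H](O)[C@@H](CO)O2)c(=O)[nH]c1=O` differs from compound 3 by vinyl in place of 2-iodoethenyl on an aromatic carbon. For the measured compounds named here, no step between measured compounds bears on this change, so the expectation in this assay is loose: a moderate move to a lower number, starting from compound 3 at 63900 nM. The expected change is a 3.2-fold lower number from compound 3 to compound 4 (0.50 log units; beyond the scatter). For compound 4 the estimated value is 20000 nM, with an expected range of 3000 nM to 100000 nM.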

Compound 4, half-maximal inhibitory concentration: 14200 nM
The estimate for compound 4 lay 1.4-fold (0.15 log units) above the measured number, and the stated range covers the measured number.
By their numbers in this assay, from the lowest: compound 4; then compounds 2 and 3 (each within the scatter of the next). At a limit, above all of these: compound 1.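

In this assay putting vinyl in place of 2-iodoethenyl gives a 4.5-fold lower number from compound 3 to compound 4 (0.65 log units; beyond the scatter) with the double bond outside the ring kept and the iodine gone. This is the first comparison among the compounds shown that isolates one place, and it shows that the number responds to a change at this aromatic carbon, two atoms from the ring nitrogen. Nothing measured here accounts for the size of the step. As far as these compounds go, what stays open is how an ethyl group, a 2-bromoethenyl group or an amine on the same carbon would read.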